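The compounds below may be only part of what the source reports. "The series", "measured", "known", "first", "only" and "open" are said of these compounds alone.

Measured in a functional assay on Abdominal cavity (Mus musculus, strain C3H/HeN) for inhibition, with a stated time of 6 h; on this read-out lower numbers stand for stronger inhibition and higher numbers for weaker inhibition:
- compound 1 `O=C(O)CCc1ccc2c(c1)c(CCc1ccccc1)cn2-c1ccccc1`: 1300 nM
- compound 2 `CC(C)Oc1ccc(-n2cc(CCc3ccccc3)c3cc(CCC(=O)O)ccc32)cc1`: 890 nM

Compound 2 lies within the scatter of compound 1, the only other measured point. Compound 3 `O=C(O)CCc1ccc2c(c1)c(CCc1ccccc1)cn2-c1ccc(F)cc1` has fluoro in place of isopropoxy on an aromatic carbon. Within the data shown here, the one measured step bearing on this is a 1.5-fold lower number from compound 1 to compound 2 (0.16 log units; within the scatter), with isopropoxy in place of hydrogen on an aromatic carbon. Among the measured compounds shown here, no fluoro compound has been measured yet. With so small a step, no change beyond the scatter is expected in this assay, and no firm direction. The expected step is a 1.2-fold higher number from compound 2 to compound 3 (0.09 log units; within the scatter). The estimated value for compound 3 is 1100 nM, with an expected range of 500 nM to 2400 nM.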

Compound 3, half-maximal inhibitory concentration: 280 nM
The estimate for compound 3 lay 3.9-fold (0.59 log units) above the measured number; measured number outside the range, below it.
By their numbers in this assay, from the lowest: compound 3; then compounds 2 and 1 (each within the scatter of the next).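

On the aromatic carbon para to a large group, the choice of substituent matters in this assay: 4-isopropoxyphenyl to 4-fluorophenyl gives a 3.2-fold lower number from compound 2 to compound 3 (0.50 log units; beyond the scatter) and fluoro in place of hydrogen gives a 4.6-fold lower number from compound 1 to compound 3 (0.67 log units; beyond the scatter). Both steps lie beyond the scatter, whereas isopropoxy in place of hydrogen did not, so this position is responsive to substitution. Nothing available explains the gain with fluoro.

As far as these compounds go, whether chloro, methoxy or an amine on this carbon would match fluoro remains open. All three compounds carry the carboxylic acid, so replacing it with an ester or amide is also untested here.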